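The compounds below may be only part of what the source reports. "The series", "measured", "known", "first", "only" and "open" are said of these compounds alone.

Measured so far:
compound 1 `CCc1cccc(NC(=O)CN2CCC(c3cccc[n+]3[O-])CC2)c1` — 95 nM
compound 2 `Cc1cccc(C(=O)NCN2CCC(c3nccs3)CC2)c1` — 9.8 nM

In a functional assay on HEK293 cells for agonist activity at D(4) dopamine receptor (Homo sapiens), read by FLIPR (a lower number here means that less compound is needed, a higher number that more compound is needed for the effect), compound 1 gives 95 nM, the higher of the two numbers. Compound 2 gives 9.8 nM, a number beyond the scatter below it, but the two structures differ in several places at once, so this gap says nothing about any single change. Compound 3 `O=C(CN1CCC(c2cccc[n+]2[O-])CC1)Nc1ccc(F)cc1` has not yet been measured. It differs from compound 1 in one place: 4-fluorophenyl in place of 3-ethylphenyl on an amide-type nitrogen. Among the compounds with values here, no measured pair shows what such a change does, so the step of a 1.1-fold higher number from compound 1 to compound 3 (0.02 log units; within the scatter) is expected to be small, within the usual scatter in either direction. Compound 3 is therefore estimated at 100 nM, with a range from 30 nM to 400 nM.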

Compound 3, half-maximal effective concentration: 85 nM
For compound 3 the middle estimate is 1.2-fold (0.07 log units) above the measured one; the range from low to high includes it.
By their numbers in this assay, from the lowest: compound 2; then compounds 3 and 1 (each within the scatter of the next).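

In this assay, the first single change measured at this position, 4-fluorophenyl in place of 3-ethylphenyl on the amide-type nitrogen, gives a 1.1-fold lower number from compound 1 to compound 3 (0.05 log units; within the scatter) and so leaves the two compounds indistinguishable. This place on the shared core therefore accepts both groups here, even though they differ in the group they carry and where it sits on the ring. Nothing available explains this result.

Still open, from the compounds shown here alone, is what a plain phenyl, with neither ethyl nor fluorine, would give on this nitrogen. Going by these compounds, a phenyl bearing an amine or a carboxylic acid is equally open.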